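The compounds below may be only part of what the source reports. "The series", "measured", "known", "first", "only" and "open" are said of these compounds alone.

Measured in a functional assay on NCI-H460 cells (Homo sapiens) for inhibition, read by sulforhodamine B assay, with a stated time of 48 h; on this read-out lower numbers stand for stronger inhibition of growth and higher numbers for weaker inhibition of growth:
- Compound 1 (`O=C(/C=C/c1ccc(OCc2ccccc2)cc1)c1ccc(O)cc1O`): 10500 nM
- Compound 2 (`COc1ccc(/C=C/C(=O)c2ccc(O)cc2O)cc1`): "not determined" (no result reported)
- Compound 3 (`O=C(/C=C/c1ccc(F)cc1)c1ccc(O)cc1O`): 15300 nM

Compound 2 has no place on these numbers. In this assay compound 2 is recorded as "not determined" (no result reported), so no single value stands for it and no measured starting point exists for the step that follows. That step leads to compound 4 (`CCCc1c(O)ccc(C(=O)/C=C/c2ccc(OC)cc2)c1O`), which has not yet been measured. The change is propyl in place of hydrogen on an aromatic carbon.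

Among the compounds with values here, only one measured step is available, a 1.5-fold higher number from compound 1 to compound 3 (0.16 log units; within the scatter). It lies within the scatter, and it is a different change, fluoro in place of benzyloxy on an aromatic carbon. Within the data shown here, no measured step involves a propyl group, so the data give neither a size nor a direction for this change, and no shift beyond the scatter can be expected with any confidence. Among the measured compounds shown here, the only guide is the level of the two measured relatives, compound 1 at 10500 nM and compound 3 at 15300 nM. Compound 4 is therefore expected to fall near that level, but with a wide margin. For compound 4 the estimated value is 10000 nM, with an expected range from 3000 nM to 30000 nM.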

Compound 4, concentration for 50% growth inhibition: 24700 nM
Compound 4: the middle estimate sits 2.5-fold (0.39 log units) below what was measured; measured number inside the range.
By their numbers in this assay, from the lowest: compounds 1, 3 and 4 (each within the scatter of the next, the first and the last beyond it).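

In this assay compound 2 carries no number, so the step from compound 2 to compound 4, propyl in place of hydrogen, cannot be read, even though compound 4 gives 24700 nM. The compounds shown leave open what this propyl group alone does to growth inhibition. No further evidence bears on this result.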